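The source may hold more compounds than are shown below. What is called first, only, known or untested is meant among the compounds shown, and "the series" means these compounds.

Working notes on the series, three compounds measured in a functional assay on PC-3 cells (Homo sapiens) for inhibition (a lower number here means a stronger inhibitor, a higher number a weaker inhibitor), and one still pending.

Compound 1 `COc1cc2nc(N3CCN(S(=O)(=O)c4ccc(C(F)(F)F)cc4)CC3)nc(N)c2cc1OC` gives 27000 nM in this assay. Compound 2 `COc1ccc(S(=O)(=O)N2CCN(c3nc(N)c4cc(OC)c(OC)cc4n3)CC2)cc1` gives 39000 nM in this assay. Compound 3 `COc1cc2nc(N3CCN(S(=O)(=O)c4ccc(-c5ccccc5)cc4)CC3)nc(N)c2cc1OC` gives 4200 nM in this assay and stands lowest of the three numbers: the step of a 6.4-fold lower number from compound 1 to compound 3 (0.81 log units; beyond the scatter) and the step of a 9.3-fold lower number from compound 2 to compound 3 (0.97 log units; beyond the scatter) both go beyond the scatter, whereas the step of a 1.4-fold higher number from compound 1 to compound 2 (0.16 log units; within the scatter) stays within it.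

Compound 4 `COc1cc2nc(N3CCN(S(=O)(=O)c4ccc(-c5ccc(C(F)(F)F)cc5)cc4)CC3)nc(N)c2cc1OC` carries the change (trifluoromethyl in place of hydrogen on an aromatic carbon). Within the data shown here, no measured step in this set exchanges hydrogen for trifluoromethyl. Among the measured compounds shown here, the only step that involves trifluoromethyl, a 1.4-fold higher number from compound 1 to compound 2 (0.16 log units; within the scatter), swaps it against methoxy on an aromatic carbon and stays within the scatter. The two steps that go beyond the scatter, a 6.4-fold lower number from compound 1 to compound 3 (0.81 log units; beyond the scatter) and a 9.3-fold lower number from compound 2 to compound 3 (0.97 log units; beyond the scatter), concern the phenyl itself, which compound 4 retains. On these grounds the expected step of a 1.1-fold lower number from compound 3 to compound 4 (0.02 log units; within the scatter) in this assay is none beyond the scatter, with no direction favoured. For compound 4 the estimated value in this assay is 4000 nM, expected to fall between 1200 nM and 13000 nM.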

Compound 4, half-maximal inhibitory concentration: 3300 nM
The estimate for compound 4 lay 1.2-fold (0.08 log units) above the measured number; measured number inside the range.
By their numbers in this assay, from the lowest: compounds 4 and 3 (each within the scatter of the next); then compounds 1 and 2 (each within the scatter of the next).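

In this assay, among these compounds, the step of a 1.3-fold lower number from compound 3 to compound 4 (0.10 log units; within the scatter) stays within the scatter, so this is the first reading at this carbon of the outer ring: trifluoromethyl on an aromatic carbon para to a large group leaves the number where hydrogen had it. The advantage of the biaryl sulfonamides over the single-ring ones also survives this substitution, with the step of an 8.2-fold lower number from compound 1 to compound 4 (0.91 log units; beyond the scatter) and the step of a 12-fold lower number from compound 2 to compound 4 (1.07 log units; beyond the scatter) both beyond the scatter, so the outer ring can carry this group without losing what the phenyl brought. No measurement in hand accounts for the flat step at this carbon or for the gain that comes with the outer ring.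

With trifluoromethyl as the only substituent shown at this carbon, one flat step cannot say whether the position is generally indifferent to what sits there, and an amine, a carboxylic acid or a longer alkyl chain could behave differently. Also open, from the compounds shown here alone, is whether other placements of trifluoromethyl on the outer ring, or a second ring other than phenyl, such as a pyridine, would hold or move the number.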